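The source may report more compounds than this note shows. Statements on the series, on what has been measured and on what is new or still open speak of the compounds shown alone.

In an ADME assay on cells (Hepatocyte, Mus musculus) for cytotoxicity, read by MTT assay, with a stated time of 24 h (a higher number here means that more compound is tolerated, a lower number that less compound is tolerated), compound 1 (`Cc1ccc(-c2nn(-c3ccccc3)cc2-c2nc3ccccc3n2S(=O)(=O)c2ccc(Cl)cc2)cc1`) gives 216000 nM and compound 2 (`Cc1ccc(C)c(S(=O)(=O)n2c(-c3cn(-c4ccccc4)nc3-c3ccc(F)cc3)nc3ccccc32)c1`) gives 122000 nM, two values within the usual scatter of each other. Compound 3 (`O=S(=O)(c1ccc(Cl)cc1)n1c(-c2cn(-c3ccccc3)nc2-c2ccc(F)cc2)nc2ccccc21`) has not yet been measured. It differs from compound 2 by 4-chlorophenyl in place of 2,5-dimethylphenyl on a sulfonyl sulfur, with 4-chlorophenyl in place of 2,5-dimethylphenyl on a sulfonyl sulfur. Compound 1, at 216000 nM, already carries 4-chlorophenyl on a sulfonyl sulfur. No change beyond the scatter is expected, and the estimated step is a 1.4-fold higher number from compound 2 to compound 3 (0.14 log units; within the scatter). Compound 3 is expected at 170000 nM, with an estimated range of 90000 nM to 320000 nM.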

Compound 3, half-maximal cytotoxic concentration: 231000 nM
Estimate against measurement, compound 3: 1.4-fold (0.13 log units) below, and the stated range covers the measured number.
By their numbers in this assay, from the lowest: compounds 2, 1 and 3 (each within the scatter of the next).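

In this assay, the first exchange read on the sulfonyl sulfur, 4-chlorophenyl in place of 2,5-dimethylphenyl, gives a 1.9-fold higher number from compound 2 to compound 3 (0.28 log units; within the scatter) and so leaves the number inside the scatter. With 4-chlorophenyl held on the sulfonyl sulfur, fluoro in place of methyl on an aromatic carbon gives a 1.1-fold higher number from compound 1 to compound 3 (0.03 log units; within the scatter) and also stays inside it. No evidence on the cause of either step is available. The compounds shown leave open whether any group on the sulfonyl sulfur moves the number beyond the scatter. On these data alone, an amine or carboxylic acid on that aromatic ring, or a longer chain in its place, remains untested here.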